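Cyclohexyl for phenyl on the hydroxyacyl arm of compound 2

This account rests on a few compounds, and the source may have more. Where it says the series, first, only, none or still open, it means among the compounds named here.

Working notes on the series. In an ADME assay on liver for metabolic stability, with Liver microsome (Homo sapiens) as the target, read by LC-MS, using microsomes (a higher number here means faster removal of the compound, a lower number slower removal), compound 1 `CC(C)(C)[C@@H](O)C(=O)N1C[S+]([O-])C[C@H]1C(=O)NCc1cc(Cl)ccc1-n1cnnn1` gives < 12 mL.min-1.g-1, which is a limit of the assay rather than a number. Compound 2 `O=C(NCc1cc(Cl)ccc1-n1cnnn1)[C@@H]1C[C@@H]2C[C@@H]2N1C(=O)[C@H](O)c1ccccc1` gives < 16 mL.min-1.g-1 in this assay, again a limit. Compound 3 `O=C(NCc1cc(Cl)ccc1-n1cnnn1)[C@@H]1C[C@H]2C[C@H]2N1C(=O)[C@H](O)c1ccccc1` gives < 15 mL.min-1.g-1 in this assay, also a limit. Compounds 2 and 3 share all atoms and bonds and differ only in configuration as drawn (the fact that compounds 2 and 3 differ only in the configuration as drawn), and the step that the two limits leave unreadable from compound 2 to compound 3 cannot be sized because both ends are limits the limit of < 15 mL.min-1.g-1 in this assay, at which 1 of the 3 values shown sits (the limit of < 16 mL.min-1.g-1 in this assay, at which 1 of the 3 values shown sits). Within the data shown here, compound 2 therefore stands at a limit, as do the other two values shown (the limit of < 12 mL.min-1.g-1 in this assay, at which 1 of the 3 values shown sits), and no measured step has a readable size.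

Compound 4 `O=C(NCc1cc(Cl)ccc1-n1cnnn1)[C@@H]1C[C@@H]2C[C@@H]2N1C(=O)[C@H](O)C1CCCCC1` differs from compound 2 in cyclohexyl in place of phenyl on a saturated chain carbon bound to a carbonyl carbon and an oxygen on a saturated carbon. Among the measured compounds shown here, no measured step bears on this change, and none of the three values shown gives a number to anchor it. With every measurement at a limit, compound 4 is expected at 14 mL.min-1.g-1, within 7 mL.min-1.g-1 to 40 mL.min-1.g-1, most likely reported again as a limit. The expected step that the limit leaves unreadable from compound 2 to compound 4 is accordingly an estimate read against a limit, not against a number.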

Compound 4, intrinsic clearance in microsomes: 150 mL.min-1.g-1
The estimate for compound 4 lay 11-fold (1.03 log units) below the measured number, outside the stated range (above it).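

In this assay, cyclohexyl in place of phenyl on a saturated chain carbon bound to a carbonyl carbon and an oxygen on a saturated carbon gives an at least 9.3-fold higher number from compound 2 to compound 4 (0.97 log units; beyond the scatter) and this step lies beyond the scatter. It is the only readable step in the series, the step between compound 2 and compound 3 being unreadable with a limit at both ends, and compound 4 is the only compound shown with a number rather than a limit. Nothing measured here accounts for the rise in clearance that accompanies this change.

As far as these compounds go, whether a cyclopentyl or a pyridyl ring at this place would read closer to compound 2 or to compound 4 remains open. Also open, from the compounds shown here alone, is whether cyclohexyl in place of phenyl would have a similar effect on compound 3.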